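The source may report more compounds than this note shows. Statements on the series, on what has been measured and on what is new or still open speak of the compounds shown alone.

Compound 1, `CCOc1cc(-c2ccc3[nH]ccc3c2)cn2c(-c3cc(OC)c(OC)c(OC)c3)nnc12`, compound 2, `COc1cc(-c2nnc3c(OC)cc(-c4ccc5[nH]ccc5c4)cn23)cc(OC)c1OC`, and compound 3, `CCOc1cc(-c2ccc3c(ccn3C)c2)cn2c(-c3cc(OC)c(OC)c(OC)c3)nnc12`, were all tested in a functional assay on HCT-116 cells (Homo sapiens) for antiproliferative activity, read by MTT assay, with a stated time of 48 h; a higher number here means a weaker inhibitor, a lower number a stronger inhibitor. In this assay compound 1 gives 374 nM, compound 2 gives 108 nM, and compound 3 gives 228 nM.

Two single changes connect these three. Between compound 1 and compound 2 the change is hydrogen in place of methyl on a saturated chain carbon bound to an oxygen on an aromatic ring, and it gives a 3.5-fold lower number from compound 1 to compound 2 (0.54 log units; beyond the scatter). Between compound 1 and compound 3 the change is methyl in place of hydrogen on an aromatic nitrogen, and it gives a 1.6-fold lower number from compound 1 to compound 3 (0.21 log units; within the scatter), which lies within the scatter of the method.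

Compound 4, `COc1cc(-c2nnc3c(OC)cc(-c4ccc5c(ccn5C)c4)cn23)cc(OC)c1OC`, has not yet been measured in this assay. It differs from compound 3 by hydrogen in place of methyl on a saturated chain carbon bound to an oxygen on an aromatic ring, the same change that separates compound 1 from compound 2, made here on the core of compound 3; the two cores differ by methyl in place of hydrogen on an aromatic nitrogen.

Because the same change gave a 3.5-fold lower number from compound 1 to compound 2 (0.54 log units; beyond the scatter) on the core of compound 1, a step of similar size is expected here, namely a 3.5-fold lower number from compound 3 to compound 4 (0.55 log units; beyond the scatter). On that basis compound 4 is estimated at 65 nM, with a range from 30 nM to 150 nM, in this assay.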

Compound 4, half-maximal inhibitory concentration: 33 nM
Compound 4: the middle estimate sits 2.0-fold (0.29 log units) above what was measured; measured number inside the range.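

In this assay the change from ethoxy to methoxy gave a 6.9-fold lower number from compound 3 to compound 4 (0.84 log units; beyond the scatter) on the core of compound 3, the same direction as on the core of compound 1, and the two steps do not differ beyond the scatter: the same change on two cores in this assay, a 3.5-fold lower number (0.54 log units; beyond the scatter) from compound 1 to compound 2 and a 6.9-fold lower number (0.84 log units; beyond the scatter) from compound 3 to compound 4, 2.0-fold (0.30 log units) apart, within the scatter of two such steps. Methyl in place of hydrogen on the aromatic nitrogen gave a 3.3-fold lower number from compound 2 to compound 4 (0.51 log units; beyond the scatter) on the methoxy core, and this step, although beyond the scatter where the earlier one was within it, also cannot be told apart from that earlier step: the same change on two cores in this assay, a 1.6-fold lower number (0.21 log units; within the scatter) from compound 1 to compound 3 and a 3.3-fold lower number (0.51 log units; beyond the scatter) from compound 2 to compound 4, 2.0-fold (0.30 log units) apart, within the scatter of two such steps. Within these four compounds, then, each change carried from one core to the other without a gap beyond the scatter, but with only two cores for each change this does not show that either step would hold on any further core, nor does it explain the sizes of the steps.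

The compounds shown leave open how a longer chain such as propoxy, or a free hydroxyl, would compare with ethoxy and methoxy. They also leave open whether an ethyl group on the aromatic nitrogen would follow the methyl.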